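Sulfonamide heteroaryl swap: thiazole to thiadiazole, solubility notes

The compounds below may be only part of what the source reports. "The series", "measured", "known", "first", "only" and "open" are said of these compounds alone.

Three compounds of the series have numbers in a physicochemical assay for solubility, read by HPLC, measured as thermodynamic solubility, with a stated time of 4 h, at pH 6.8; on this read-out lower numbers stand for lower solubility and higher numbers for higher solubility. Compound 1 `Cc1cc(S(=O)(=O)Nc2ccncn2)c(F)cc1O[C@H]1CCC[C@@H]1c1ccnn1C` gives 1200000 nM in this assay, the highest of the three. Compound 3 `Cn1nccc1[C@H]1CCC[C@@H]1Oc1ccc(S(=O)(=O)Nc2ccncn2)c(F)c1F` gives 550000 nM. Compound 2 `Cn1nccc1[C@H]1CCC[C@@H]1Oc1cc(F)c(S(=O)(=O)Nc2nccs2)cc1F` gives 250000 nM, the lowest of the three numbers; its gap to compound 3 is the nearest and already beyond the usual scatter, and its gap to compound 1 is the widest. Among the compounds with values here, the three differ in more than one place, so no single step between them is separated out here.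

The next compound, compound 4 `Cn1nccc1[C@H]1CCC[C@@H]1Oc1cc(F)c(S(=O)(=O)Nc2ncns2)cc1F`, is not yet measured. It differs from compound 2 in one place only: 1,2,4-thiadiazol-5-yl in place of 1,3-thiazol-2-yl on a sulfonamide nitrogen. Both rings keep the same count of heavy atoms; the entering ring carries one more hetero atom and one more hydrogen-bond acceptor, with no change in donors or in charge.

Within the data shown here, no measured pair shows this exact exchange, so the size of the step rests on the change alone. The expectation is a small rise in this assay from compound 2 to compound 4, of a size near or just beyond the scatter, a 1.6-fold higher number from compound 2 to compound 4 (0.20 log units; within the scatter). Compound 4 is therefore estimated at 400000 nM, within the range 150000 nM to 1100000 nM.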

Compound 4, solubility: > 1900000 nM
Compound 4 was reported as a limit; the forecaster's own chance of this, stated with the estimate: 5%; at least 4.7-fold (0.67 log units) between middle value and limit.
By their numbers in this assay, from the lowest: compound 2; then compound 3; then compound 1. At a limit, above all of these: compound 4.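

In this assay compound 4 gives > 1900000 nM, which is a limit of the assay and not a number. Within the data shown here, the exchange of 1,3-thiazol-2-yl for 1,2,4-thiadiazol-5-yl on a sulfonamide nitrogen comes with an at least 7.6-fold higher number from compound 2 to compound 4 (0.88 log units; beyond the scatter), the first step that isolates a single place, and its size is bounded on one side only: the limit of > 1900000 nM in this assay, at which 1 of the 4 values shown sits. The counted differences are limited to one more hetero atom and one more hydrogen-bond acceptor in the entering ring, with heavy atoms, donors and net charge unchanged, and these counts alone do not establish a cause for the step.

The compounds shown leave open whether the same exchange carries a comparable step on the core of compound 1 or the core of compound 3, since neither is paired here with a thiazole or thiadiazole partner. They also leave open how 1,3,4-thiadiazol-2-yl, 1,2,4-oxadiazol-5-yl or a thiadiazole bearing a methyl group or an amine would read on the same sulfonamide nitrogen.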